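The source may hold more compounds than are shown below. What is called first, only, known or untested is meant among the compounds shown, and "the series" means these compounds.

Compound 1 `COC(=O)C1CC2CC1N(C)C2` reaches 82% in a functional assay on the whole organism (Superior cervical ganglion) with Rattus norvegicus as the target; on this read-out lower numbers stand for smaller maximal responses and higher numbers for larger maximal responses. Compound 2 `COC(=O)[C@@H]1C[C@@H]2C[C@H]1N(C)C2` reaches 70% in this assay, and compound 3 `COC(=O)C1CC2CNC1C2` reaches 57% in this assay, the lowest of the three numbers, standing below compound 2 and below compound 1. Two steps have been measured: from compound 1 to compound 2 the drawing of configuration at three ring carbons gives a number 12 percentage points lower from compound 1 to compound 2 (beyond the scatter), a step that goes together with the fact that one of compounds 1 and 2 is drawn with a defined configuration and the other without, at the place where they differ, and from compound 1 to compound 3 the exchange of hydrogen for methyl on the ring amine nitrogen gives a number 25 percentage points lower from compound 1 to compound 3 (beyond the scatter). Compound 4 `COC(=O)[C@@H]1C[C@H]2CN[C@@H]1C2` is the counterpart of compound 3 with configurations drawn: the two compounds have the same atoms and bonds; at least one stereo element is drawn with a configuration in one of them and without one in the other: 3 of 3 stereo elements differ; a stereocentre at a saturated ring carbon is drawn without a configuration in compound 3 and R in compound 4; a stereocentre at a saturated ring carbon is drawn without a configuration in compound 3 and R in compound 4; a stereocentre at a saturated ring carbon is drawn without a configuration in compound 3 and R in compound 4. Among the compounds with values here, the only step that bears on this change is the one from compound 1 to compound 2, which was modest and downward. A step of similar size and direction is therefore expected from compound 3 to compound 4, namely a number 11 percentage points lower from compound 3 to compound 4 (beyond the scatter). Compound 4 is estimated to reach 46% in this assay, within a range from 32% to 62%.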

Compound 4, largest response reached (reported as efficacy), in percent of the reference or control that the assay uses: 90%
Estimate against measurement, compound 4: 44 percentage points below; measured number above the stated range.
By their numbers in this assay, from the lowest: compound 3; then compound 2; then compounds 1 and 4 (each within the scatter of the next).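

The step of a number 33 percentage points higher from compound 3 to compound 4 (beyond the scatter) runs the opposite way to a number 12 percentage points lower from compound 1 to compound 2 (beyond the scatter), so drawing a configuration on these compounds has no fixed direction in this assay. Hydrogen in place of methyl on the ring amine nitrogen also changes direction once configuration is drawn, giving a number 20 percentage points higher from compound 2 to compound 4 (beyond the scatter), and the earlier step on the undrawn pair therefore does not carry over: the same change on two cores in this assay, a number 25 percentage points lower (beyond the scatter) from compound 1 to compound 3 and a number 20 percentage points higher (beyond the scatter) from compound 2 to compound 4, 45 percentage points apart, beyond the scatter of two such steps. The size of the new step may be tied to how the two structures are drawn, though the numbers alone cannot settle this: the fact that one of compounds 3 and 4 is drawn with a defined configuration and the other without, at the place where they differ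

As far as these compounds go, what the compounds with the opposite drawn configuration would reach remains open. Also open, from the compounds shown here alone, is how an ethyl group on the ring amine nitrogen, or a carboxylic acid in place of the methyl ester, would behave on the core of compound 4.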